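Putting an aromatic ring back on the carbonyl carbon

A few compounds are considered here, and "the series" means these few. Any claim that something is new, unique, unknown or untested is made for them only; others in the source may bear on it.

In a functional assay on HepG2 cells (Homo sapiens) for inhibition, read by MTT assay, with a stated time of 48 h (a higher number here means a weaker inhibitor, a lower number a stronger inhibitor), compound 1 `COc1ccc(-n2c(SCC(=O)c3ccccc3)nnc2-c2cc(OC)c(OC)c(OC)c2)cc1` gives 16200 nM, a measured value. Compound 2 `COc1ccc(-n2c(SCC(=O)C3CC3)nnc2-c2cc(OC)c(OC)c(OC)c2)cc1` gives > 60000 nM, which is a limit and not a number. Its true position is therefore known only from one side.

The next structure, compound 3 `COc1ccc(-n2c(SCC(=O)Nc3ccc(Cl)cc3)nnc2-c2cc(OC)c(OC)c(OC)c2)cc1`, carries (4-chlorophenyl)amino in place of cyclopropyl on a carbonyl carbon. Among the compounds with values here, one measured step bears on this change, an at least 3.7-fold higher number from compound 1 to compound 2 (0.56 log units; beyond the scatter), which lies beyond the scatter and came with the loss of the phenyl ring on that same carbonyl carbon. Compound 3 brings a six-membered aromatic ring back there, though joined through the amino group, so it need not behave like compound 1. A move to a lower number in this assay, of about the same size, is expected: an at least 4.0-fold lower number from compound 2 to compound 3 (0.60 log units; beyond the scatter). For compound 3 the estimated value is 15000 nM, with an expected range of 4000 nM to 55000 nM.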

Compound 3, half-maximal inhibitory concentration: > 60000 nM
Compound 3: no number, only a limit; the forecaster's own chance of this, stated with the estimate: 15%; at least 4.0-fold (0.60 log units) between middle value and limit.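

In this assay compound 3 gives > 60000 nM, which is a limit and not a number. Putting (4-chlorophenyl)amino in place of phenyl on the carbonyl carbon gives an at least 3.7-fold higher number from compound 1 to compound 3 (0.56 log units; beyond the scatter), so in this pair a six-membered aromatic ring joined through the amino group does not match the directly attached phenyl ring. The step linking compound 2 and compound 3 cannot be read because both stand at the same limit: the limit of > 60000 nM in this assay, at which 2 of the 3 values shown sit.

On these data alone, it remains open whether the amino group, the chlorine or both set compound 3 apart from compound 1. A plain phenylamino group, or a 4-chlorophenyl group joined directly to the carbonyl carbon, would separate these two parts of the change.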